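Hydroxymethyl for Butoxy in a Series Sitting at the Limit

The source may report more compounds than this note shows. Statements on the series, on what has been measured and on what is new or still open speak of the compounds shown alone.

Of the compounds shown here, three sharing one core have been tested in an ADME assay on Raji cells (Homo sapiens) for cytotoxicity, read by luminescence, with a stated time of 72 h; on this read-out higher numbers stand for an effect only at larger amounts of compound and lower numbers for an effect already at smaller amounts. Compound 1 `CCOC(=O)c1c(-c2cc(F)cc(OC)c2)[nH]c2cc(OC)ccc2c1=O` returns only the limit of the assay, > 21500 nM. Compound 2 `CCOC(=O)c1c(-c2cccc(C)c2)[nH]c2cc(OC)ccc2c1=O` likewise gives the limit, > 21500 nM. Compound 3 `CCCCOc1cccc(-c2[nH]c3cc(OC)ccc3c(=O)c2C(=O)OCC)c1` also sits at the limit, with > 21500 nM. Because every value shown ends at the limit of > 21500 nM in this assay, at which 3 of the 3 values shown sit, the steps a step that the two limits leave unreadable from compound 1 to compound 2 and a step that the two limits leave unreadable from compound 2 to compound 3 cannot be sized. Compound 4 `CCOC(=O)c1c(-c2cccc(CO)c2)[nH]c2cc(OC)ccc2c1=O` has not yet been measured; it differs from compound 3 by hydroxymethyl in place of butoxy on an aromatic carbon. Among the compounds with values here, no measured step bears on this change. Given that all values so far rest at the limit of > 21500 nM in this assay, at which 3 of the 3 values shown sit, compound 4 is expected to give 40000 nM, within a range from 15000 nM to 150000 nM. The expected step is a step that the limit leaves unreadable from compound 3 to compound 4, nothing beyond the scatter.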

Compound 4, half-maximal effective concentration: > 21500 nM
Compound 4 ended at the assay's limit; the forecaster's own chance of this, stated with the estimate: 85%; the middle value does not contradict the limit.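

Within the data shown here, no step between compound 1, compound 2, compound 3 and compound 4 can be read in this assay, since each gives only a limit, not a number: the limit of > 21500 nM in this assay, at which 4 of the 4 values shown sit.

Left open is the amount at which any of these compounds would show an effect in this assay, and whether they differ from one another at all.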